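Replacing the methylpiperidine of compound 1 with a butanamide

The source may hold more compounds than are shown below. What is called first, only, known or untested is meant among the compounds shown, and "the series" means these compounds.

Compound 1 `Cc1cc(C)c(S(=O)(=O)N2CCC(N3CCC(C)CC3)CC2)c(C)c1` is the strongest compound in this set. In a functional assay on DLD-1 cells (Homo sapiens) for antiproliferative activity, read by CellTiter-Glo, with a stated time of 72 h (on this read-out lower numbers stand for stronger inhibition and higher numbers for weaker inhibition), compound 1 gives 0.03 nM, the lowest number among the three measured compounds. Its nearest neighbour is compound 3 `Cc1cc(C)c(S(=O)(=O)N2CCC(N3CCC(Cc4ccc(F)cc4)CC3)CC2)c(C)c1`, which in this assay gives 18 nM, a change of a 600-fold higher number from compound 1 to compound 3 (2.78 log units; beyond the scatter). Further away stands compound 2 `Cc1cc(C)c(S(=O)(=O)N2CCC(N3CCC(c4ccccc4)CC3)CC2)c(C)c1`, which gives 865 nM, a change of a 29000-fold higher number from compound 1 to compound 2 (4.46 log units; beyond the scatter). Between those two, the change of a 48-fold lower number from compound 2 to compound 3 (1.68 log units; beyond the scatter) shows that the choice of group on that distant saturated ring carbon matters a great deal.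

Compound 4 `CCCC(=O)NC1CCN(S(=O)(=O)c2c(C)cc(C)cc2C)CC1` differs from compound 1 in one place: (propylcarbonyl)amino in place of 4-methylpiperidin-1-yl on a saturated ring carbon. Both measured steps from compound 1 altered the same outer ring and cost a great deal of activity; here the whole ring is gone and a short chain with an amide takes its place, an even more sweeping change at the same position. A large loss in this assay is therefore expected, although nothing measured here tells how far it will go. For compound 4 the estimated value is 1000 nM, within a range from 30 nM to 30000 nM. That estimate corresponds to an expected step of a 33000-fold higher number from compound 1 to compound 4 (4.52 log units; beyond the scatter).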

Compound 4, half-maximal inhibitory concentration: > 5000 nM
Compound 4: a limit, no number (the forecaster's own chance of this, stated with the estimate: 25%); at least 5.0-fold (0.69 log units) between middle value and limit.
By their numbers in this assay, from the lowest: compound 1; then compound 3; then compound 2. At a limit, above all of these: compound 4.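

Compound 4 gives > 5000 nM in this assay, and this is a limit of the assay, not a number. Swapping the whole 4-methylpiperidin-1-yl ring for the open-chain (propylcarbonyl)amino group gives an at least 160000-fold higher number from compound 1 to compound 4 (5.22 log units; beyond the scatter), and the true size of this step may be larger still. Compound 2 and compound 3 kept the outer ring and changed only what it carries, and both still gave a measurable number, so this is the first change at this position to leave the measurable range, a result that rests on one compound: the limit of > 5000 nM in this assay, at which 1 of the 4 values shown sits.

This single change removes the ring and also brings in a carbonyl and an amide hydrogen, so the compounds shown cannot tell whether losing the ring or gaining the amide costs the activity. An open-chain amine such as diethylamino on this saturated ring carbon would help to separate those two, while a plain piperidin-1-yl group would show what the methyl of compound 1 itself contributes.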